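Dichlorophenyl Carbamate: Will It Inhibit Where Others Did Not?

The compounds below may be only part of what the source reports. "The series", "measured", "known", "first", "only" and "open" are said of these compounds alone.

Measured compounds:
compound 1 `CCC(COc1cccc(Cl)c1)OC(=O)NCc1ccccc1`: > 100000 nM
compound 2 `CCC(COc1cccc(OC)c1)OC(=O)NCc1ccccc1`: > 100000 nM

In an assay for inhibition of zeta-carotene desaturase, chloroplastic/chromoplastic (Capsicum annuum), using a Dixon plot, with a stated time of 8 h (on this read-out lower numbers stand for stronger inhibition and higher numbers for weaker inhibition), compound 1 gives > 100000 nM, which is a limit of the assay rather than a number. Compound 2 gives > 100000 nM, also a limit. So a step that the two limits leave unreadable from compound 1 to compound 2, and the limit of > 100000 nM in this assay, at which 2 of the 2 values shown sit, is all that compound 2 stands on. Compound 3 `CCC(COc1cc(Cl)ccc1Cl)OC(=O)NCc1ccccc1` carries 2,5-dichlorophenyl in place of 3-methoxyphenyl on an oxygen on a saturated carbon. Among the compounds with values here, no measured step speaks to this change, so the expectation in this assay is a step that the limit leaves unreadable from compound 2 to compound 3, most likely again a limit. Compound 3 is therefore estimated at 150000 nM, within 30000 nM to 600000 nM.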

Compound 3, half-maximal inhibitory concentration: > 100000 nM
Compound 3 was reported as a limit; the forecaster's own chance of this, stated with the estimate: 80%; the middle value lies beyond the limit too.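

Compound 3 gives > 100000 nM which is a limit of the assay, as with compound 1 and compound 2, so no step among these three compounds can be read. Which change to the shared core, if any, would give a measurable value in this assay stays open.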